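Methylseleno quinazoline series: removing the methoxy from compound 1

The compounds below may be only part of what the source reports. "The series", "measured", "known", "first", "only" and "open" are said of these compounds alone.

Two compounds of the series have numbers in a functional assay on HT-29 cells (Homo sapiens) for cytotoxicity, read by MTT assay, with a stated time of 72 h (on this read-out lower numbers stand for stronger inhibition of growth and higher numbers for weaker inhibition of growth), so far. Compound 1 `COc1ccc(CNc2nc([Se]C)nc3ccccc23)cc1` gives 73600 nM in this assay. Compound 2 `COc1ccc(CNc2nc([SeH])nc3ccccc23)cc1`, which carries hydrogen in place of methyl on the selenium, gives 71600 nM in this assay. The step of a 1.0-fold lower number from compound 1 to compound 2 (0.01 log units; within the scatter) shows that the two compounds sit together in this assay, with no separation beyond the scatter; compound 1 is therefore not set apart from compound 2 on the numbers shown.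

Compound 3 `C[Se]c1nc(NCc2ccccc2)c2ccccc2n1` has not been measured in this assay. It differs from compound 1 in one place: hydrogen in place of methoxy on an aromatic carbon. Among the compounds with values here, no measured step bears on this change; the only step so far, from compound 1 to compound 2, concerns the group on the selenium and says nothing about the methoxy on the aromatic ring. With nothing to anchor a shift in either direction, the step from compound 1 to compound 3 is expected to stay within the scatter, as a 1.1-fold higher number from compound 1 to compound 3 (0.04 log units; within the scatter). Compound 3 is therefore estimated at 80000 nM in this assay, with a range from 35000 nM to 180000 nM.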

Compound 3, concentration for 50% growth inhibition: 42800 nM
For compound 3 the middle estimate is 1.9-fold (0.27 log units) above the measured one, within the range that was stated.
By their numbers in this assay, from the lowest: compounds 3, 2 and 1 (each within the scatter of the next).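

Hydrogen in place of methoxy on an aromatic carbon, para to a large group, gives a 1.7-fold lower number from compound 1 to compound 3 (0.24 log units; within the scatter) in this assay. Within the data shown here, this is the first reading at this position of the ring, and it leaves compound 3, at 42800 nM, unseparated from compound 1, so on these numbers the methoxy can be lost from this place without a shift that stands beyond the scatter; the earlier step concerned only the group on the selenium and could not show this. No supporting data bear on this result, and the step is recorded here only as a measured comparison of one pair.

Among these compounds, open is whether any other group on this aromatic carbon, such as an amine, a carboxylic acid, a chlorine atom or a longer alkoxy chain, would separate from compound 1 in this assay, since hydrogen and methoxy are the only two groups compared at this place. Also open, as far as these compounds go, is whether the same exchange would read the same way in a compound carrying hydrogen in place of methyl on the selenium, or in a cell line other than the one used here.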